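The compounds below may be only part of what the source reports. "The series", "measured", "known", "first", "only" and "open" are said of these compounds alone.

Working notes on the series. In a functional assay on MCF7 cells (Homo sapiens) for antiproliferative activity, read by sulforhodamine B assay, with a stated time of 48 h (on this read-out lower numbers stand for stronger inhibition and higher numbers for weaker inhibition), compound 1 `O=C1NCCN1c1ccc(S(=O)(=O)Nc2ccc3[nH]ccc3c2)cc1` gives 170 nM and compound 2 `Cc1cccc(NS(=O)(=O)c2ccc(N3CCNC3=O)cc2)c1` gives 190 nM, two values within the scatter of each other. Compound 3 `CCCCc1ccc(NS(=O)(=O)c2ccc(N3CCNC3=O)cc2)cc1` gives 770 nM, which lies beyond the scatter from compound 2 on the weaker side. Compound 2 therefore sits level with compound 1 and well clear of compound 3.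

The next compound is compound 4 `Cc1ccc(NS(=O)(=O)c2ccc(N3CCNC3=O)cc2)cc1C`, which differs from compound 2 by one change: methyl in place of hydrogen on an aromatic carbon. This places methyl in place of hydrogen on an aromatic carbon, ortho to a methyl group and para to a large group, turning 3-methylphenyl into 3,4-dimethylphenyl.

For the measured compounds named here, no two measured compounds differ in one place, so the size of this change has not been observed directly. Going by the values given here, the only guide is compound 3 at 770 nM, which carries a butyl chain and reads weaker, and one compound is thin ground. The expected result is a 1.3-fold higher number from compound 2 to compound 4 (0.12 log units; within the scatter), estimated as a small move toward a higher number, probably within the scatter. For compound 4 the estimated value is 250 nM, with an expected range of 110 nM to 550 nM.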

Compound 4, half-maximal inhibitory concentration: 230 nM
Estimate against measurement, compound 4: 1.1-fold (0.04 log units) above; low and high end bracket the measured number.
By their numbers in this assay, from the lowest: compounds 1, 2 and 4 (each within the scatter of the next); then compound 3.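

For the compounds shown here, the step of methyl in place of hydrogen on an aromatic carbon, ortho to a methyl group and para to a large group, gives a 1.2-fold higher number from compound 2 to compound 4 (0.08 log units; within the scatter) in this assay, and it is the first single-place comparison. Turning 3-methylphenyl into 3,4-dimethylphenyl therefore leaves the read-out level, so this place accepts one added methyl without a change that can be told from the scatter. No measured evidence bears on this result.

A single step at a single place leaves open what an amine, a carboxylic acid or a longer chain would do there in place of methyl. It also leaves open whether the same methyl step would read level starting from any compound other than compound 2.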